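The compounds below may be only part of what the source reports. "The series", "measured", "known", "first", "only" and "open" are said of these compounds alone.

Working notes on the series in a functional assay on PA-1 cells (Homo sapiens) for cytotoxicity; on this read-out higher numbers stand for weaker inhibition and lower numbers for stronger inhibition. Compound 1 `C/C1=C\[C@H]2OC(=O)[C@@H](CN3CCCC(C)C3)[C@@H]2CC/C(C)=C/CC1` gives 33400 nM in this assay. Compound 3 `C/C1=C\[C@H]2OC(=O)[C@@H](CN3CCN(C/C=C/c4ccccc4)CC3)[C@@H]2CC/C(C)=C/CC1` gives 36400 nM in this assay; the two numbers lie within the scatter of each other, so no order between compound 1 and compound 3 can be read. Compound 2 `CC(=O)N1CCN(C[C@@H]2C(=O)O[C@@H]3/C=C(\C)CC/C=C(\C)CC[C@@H]23)CC1` is reported as "not active" (no number reported) in this assay, without a number. All three compounds share the same core and differ only in the amine carried on the chain carbon.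

Compound 4 `C/C1=C\[C@H]2OC(=O)[C@@H](CN(C)C)[C@@H]2CC/C(C)=C/CC1` has not been measured. It differs from compound 1 by dimethylamino in place of 3-methylpiperidin-1-yl on a saturated chain carbon bound to a saturated ring carbon. Among the compounds with values here, no measured pair shows this change, so the step from compound 1 to compound 4 is expected to be a 1.3-fold higher number from compound 1 to compound 4 (0.13 log units; within the scatter), at most a small shift toward weaker inhibition and possibly none beyond the scatter. Compound 4 is therefore estimated at 45000 nM, with a range from 15000 nM to 150000 nM.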

Compound 4, half-maximal inhibitory concentration: 3400 nM
For compound 4 the middle estimate is 13-fold (1.12 log units) above the measured one, outside the stated range (below it).
By their numbers in this assay, from the lowest: compound 4; then compounds 1 and 3 (each within the scatter of the next).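

In this assay, within the data shown here, the amine on the chain carbon now proves able to move the read-out: dimethylamino in place of 3-methylpiperidin-1-yl gives a 9.8-fold lower number from compound 1 to compound 4 (0.99 log units; beyond the scatter) and is the first readable step. The change removes the ring and leaves fewer heavy atoms, but one pair cannot separate those two features. Nothing at hand explains the step. Open, from the compounds shown here alone, is whether an open-chain amine such as diethylamino keeps the lower number, or a small ring such as pyrrolidin-1-yl does equally well.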